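A few compounds are considered here, and "the series" means these few. Any claim that something is new, unique, unknown or untested is made for them only; others in the source may bear on it.

Working notes on the series. Compound 1 `COc1nc2ccc(Br)cc2cc1C(c1ccccc1)n1cc(-c2ccccc2)nn1` gives 13.9% in an ADME assay on HeLa cells (Homo sapiens) for cytotoxicity, read by sulforhodamine B assay, with a stated time of 48 h, tested at 10 uM; on this read-out higher numbers stand for more inhibition at the one concentration tested (going by the name of the read-out) and lower numbers for less inhibition. Compound 2 `CCOC(=O)c1cn(C(c2ccccc2)c2cc3cc(Br)ccc3nc2OC)nn1` gives -3.67% in this assay, and compound 3 `CCCc1cn(C(c2ccccc2)c2cc3cc(Br)ccc3nc2OC)nn1` gives -2.25%. Compound 3 thus stands second of the three numbers, close to compound 2, since a number 1.4 percentage points higher from compound 2 to compound 3 (within the scatter), and well under compound 1. Compound 4 `COc1nc2ccc(Br)cc2cc1C(c1ccccc1)n1cc(-c2ccc(OC(F)(F)F)cc2)nn1` differs from compound 3 by 4-(trifluoromethoxy)phenyl in place of propyl on an aromatic carbon. For the measured compounds named here, the measured step that bears on this change is the one from compound 1 to compound 3, where a number 16.2 percentage points lower from compound 1 to compound 3 (beyond the scatter); compound 4 roughly reverses it, returning an aryl group to the position where compound 1 carries phenyl. A rise of about that size toward the level of compound 1 is therefore expected in this assay. For compound 4 the estimate is 12%, with a range from 0% to 25%, an expected step of a number 14.3 percentage points higher from compound 3 to compound 4 (beyond the scatter).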

Compound 4, a percentage reported as inhibition, at one concentration (the size of the read-out at that concentration, not a potency): -2.24%
Beside the measured number, compound 4's estimate is 14.2 percentage points above it; the measured number lies below the stated range.
By their numbers in this assay, from the lowest: compounds 2, 3 and 4 (each within the scatter of the next); then compound 1.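

In this assay, returning an aryl group to this position does not by itself restore the number of compound 1: 4-(trifluoromethoxy)phenyl reads like propyl (a number 0 percentage points higher from compound 3 to compound 4 (within the scatter)) and like ethoxycarbonyl (a number 1.4 percentage points higher from compound 2 to compound 4 (within the scatter)). On the phenyl group of compound 1, trifluoromethoxy in place of hydrogen is enough to remove the gap to those compounds (a number 16.1 percentage points lower from compound 1 to compound 4 (beyond the scatter)). No measurement on hand explains this.

Still open, as far as these compounds go, is whether a smaller substituent on that phenyl group, such as fluorine or methyl, keeps the number of compound 1. Also open, from the compounds shown here alone, is how an amine or a carboxylic acid would read at this position.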